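Cytotoxicity in a Biaryl Amide Series: Third Aryl Swap

The compounds below may be only part of what the source reports. "The series", "measured", "known", "first", "only" and "open" are said of these compounds alone.

Compound 3 `CC(C)N(Cc1cccc(OCCCCCC(=O)O)c1)C(=O)c1ccc(-c2ccc3c(c2)OCCO3)cc1` carries the shared core with 2,3-dihydro-1,4-benzodioxin-6-yl on an aromatic carbon. In an ADME assay on Raji cells (Homo sapiens) for cytotoxicity, read by CellTiter-Glo and resazurin assay, with a stated time of 72 h (a lower number here means that less compound is needed, a higher number that more compound is needed for the effect), compound 3 gives only a limit, > 21900 nM. Compound 1 `CC(C)N(Cc1cccc(OCCCCCC(=O)O)c1)C(=O)c1ccc(-c2cccc3ccccc23)cc1` likewise stops at the limit > 26000 nM in this assay. Compound 2 `CC(C)N(Cc1cccc(OCCCCCC(=O)O)c1)C(=O)c1ccc(-c2ccoc2)cc1` also reaches only the limit > 26000 nM. The steps a step that the two limits leave unreadable from compound 1 to compound 2, a step that the two limits leave unreadable from compound 1 to compound 3 and a step that the two limits leave unreadable from compound 2 to compound 3 are all of unreadable size, since the limit of > 26000 nM in this assay, at which 2 of the 3 values shown sit, and the limit of > 21900 nM in this assay, at which 1 of the 3 values shown sits, place every value at the ceiling of the assay. Compound 4 `CC(C)N(Cc1cccc(OCCCCCC(=O)O)c1)C(=O)c1ccc(-c2cccc(S(C)(=O)=O)c2)cc1` varies the same position: 3-(methylsulfonyl)phenyl in place of 2,3-dihydro-1,4-benzodioxin-6-yl on an aromatic carbon. Within the data shown here, no measured step reads on this swap, so no step beyond the scatter is expected. Compound 4 is expected again at the limit, 30000 nM, within 15000 nM to 80000 nM. The expected step that the limit leaves unreadable from compound 3 to compound 4 is of no readable size.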

Compound 4, half-maximal effective concentration: > 26000 nM
Compound 4 ended at the assay's limit; the forecaster's own chance of this, stated with the estimate: 85%; the middle value is on the limit's open side.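

In this assay, among these compounds, compound 4 stands only at a limit, as do compound 1, compound 2 and compound 3, and no step among them can be read. The compounds shown leave open whether any aryl group on the shared core reaches a measurable half-maximal effective concentration in this assay.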